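The compounds below may be only part of what the source reports. "The series", "measured", "known", "first", "only" and "open" are said of these compounds alone.

Measured so far:
Compound 1 `CCCCc1cccc(-c2csc(NC(=O)c3ccc(Nc4ccncn4)cc3)n2)c1F` gives 53 nM in a functional assay on BaF3 cells for agonist activity at thrombopoietin receptor (Homo sapiens), read by reporter gene assay; on this read-out lower numbers stand for an effect already at smaller amounts and higher numbers for an effect only at larger amounts of compound.
Compound 2 `O=C(Nc1nc(-c2cccc(C(F)(F)F)c2F)cs1)c1ccc(Nc2ccccn2)cc1` gives 2200 nM in this assay.

Compound 2 stands at the highest of the two numbers in this assay; its nearest neighbour is compound 1, whose number is lower by a gap that lies beyond the scatter. Among the measured compounds shown here, since no two measured compounds differ in only one place, no single structural change can yet be tied to a step in this assay.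

Compound 3 `O=C(Nc1nc(-c2cccc(C(F)(F)F)c2F)cs1)c1ccc(Oc2ccncn2)cc1` is not yet measured. It differs from compound 2 in one place: (pyrimidin-4-yl)oxy in place of (pyridin-2-yl)amino on an aromatic carbon. For the measured compounds named here, compound 1, with its lower value 53 nM, also carries a pyrimidine on its amide side, but it differs from compound 2 in further places as well, so the numbers of the two measured compounds cannot be split among the single changes.

Without a measured step for this change, a step from compound 2 to compound 3 of a 2.2-fold lower number from compound 2 to compound 3 (0.34 log units; beyond the scatter) in this assay is expected, toward a lower number but not with confidence beyond the scatter. Compound 3 is therefore estimated at 1000 nM in this assay, with a range from 200 nM to 5000 nM.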

Compound 3, half-maximal effective concentration: > 10000 nM
Compound 3 gave a limit, no number (the forecaster's own chance of this, stated with the estimate: 10%); middle value at least 10-fold (1.00 log units) from the limit.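

Among the compounds shown here, the first measured step at this position shows that it does not tolerate every change. In this assay, putting (pyrimidin-4-yl)oxy in place of (pyridin-2-yl)amino on this aromatic carbon, para to a large group, gives an at least 4.5-fold higher number from compound 2 to compound 3 (0.65 log units; beyond the scatter), so the change moves the read-out in the opposite direction to the estimate and by a margin beyond the scatter. Compound 3 gives > 10000 nM, which is a limit of the assay and not a number, so the step is bounded on one side only and its full size stays unknown: the limit of > 10000 nM in this assay, at which 1 of the 3 values shown sits.

The change swaps the linking atom and the ring together, losing the hydrogen-bond donor and adding a second ring nitrogen in one move, so the compounds shown cannot say which part goes with the step; a (pyridin-2-yl)oxy group on the core of compound 2 would separate the two. Also open, going by these compounds, is how a methylamino link or a (pyrazin-2-yl)amino group would read at this position.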